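The compounds below may be only part of what the source reports. "The series", "measured", "known", "first", "only" and "open" are said of these compounds alone.

Measured compounds:
Compound 1 `C=C1CCC2[C@](C)(CO)[C@H](O)CC[C@@]2(C)[C@@H]1CCn1ccnc1`; in a functional assay on RAW264.7 cells (Mus musculus) for inhibition, read by Griess assay, with stated times of 3 h and 24 h (on this read-out higher numbers stand for weaker inhibition and lower numbers for stronger inhibition), compound 1 gives > 50000 nM, which is a limit of the assay, not a number.
Compound 2 `C=C1CCC2[C@](C)(CO)[C@H](O)CC[C@@]2(C)[C@@H]1CCOc1ccc2oc(-c3ccccc3)cc(=O)c2c1`; in this assay compound 2 gives > 100000 nM, also a limit of the assay.

Going by the values given here, compound 1 therefore stands at a limit, and the only other value shown is a limit as well the limit of > 50000 nM in this assay, at which 1 of the 2 values shown sits (the limit of > 100000 nM in this assay, at which 1 of the 2 values shown sits), so no order between the two can be read. Compound 3 `C=C1CCC2[C@](C)(CO)[C@H](O)CC[C@@]2(C)[C@@H]1CCOc1ccc(Br)cc1` differs from compound 1 in one place: 4-bromophenoxy in place of 1H-imidazol-1-yl on a saturated chain carbon, two bonds along the chain from a saturated ring carbon. Among the compounds with values here, no step between measured compounds is known. The step from compound 1 to compound 3 in this assay is expected to be an at least 1.2-fold lower number from compound 1 to compound 3 (0.09 log units; that floor lies within the scatter), no more than the usual scatter. Compound 3 is estimated at 40000 nM, in the range 10000 nM to 150000 nM, with a limit rather than a number the likelier outcome.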

Compound 3, half-maximal inhibitory concentration: 40300 nM
For compound 3 the middle estimate is 1.0-fold (0.00 log units) below the measured one; low and high end bracket the measured number.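

In this assay compound 3 is the first compound shown with a number rather than a limit, so this chain position can carry a group that gives a readable value. Placing 4-bromophenoxy here in place of 1H-imidazol-1-yl gives an at least 1.2-fold lower number from compound 1 to compound 3 (0.09 log units; that floor lies within the scatter). Compound 1 stands at a limit of the assay, so only a floor for this step can be read: the limit of > 50000 nM in this assay, at which 1 of the 3 values shown sits.

As far as these compounds go, what the bromine contributes, as against the phenoxy group alone, stays open; plain phenoxy or 4-chlorophenoxy would separate the two. From the compounds shown here alone, the effect of an amine or a longer chain at this position also remains unknown.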